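This account rests on a few compounds, and the source may have more. Where it says the series, first, only, none or still open, it means among the compounds named here.

Compound 2, `Oc1ccc(-c2cc(-c3cccc(O)c3)nc(-c3cccc(O)c3)c2)cc1`, stands lowest of the three numbers in an ADME assay on HEK293 cells (Homo sapiens) for cytotoxicity, read by CCK-8 assay, with a stated time of 4 days; on this read-out lower numbers stand for stronger inhibition and higher numbers for weaker inhibition: compound 2 gives 730 nM, while compound 1, `Oc1ccc(-c2cc(-c3cccc(O)c3)nc(-c3ccccc3O)c2)cc1`, gives 7420 nM and compound 3, `Oc1ccc(-c2cc(-c3ccc(O)cc3)nc(-c3ccccc3O)c2)cc1`, gives 26300 nM. Compound 4, `Oc1cccc(-c2cc(-c3ccccc3O)cc(-c3cccc(O)c3)n2)c1`, has the same atoms as compound 2 joined differently: 2-hydroxyphenyl in place of 4-hydroxyphenyl on an aromatic carbon. Among the measured compounds shown here, two measured steps bear on this change. The step of a 10-fold lower number from compound 1 to compound 2 (1.01 log units; beyond the scatter) shows that a 3-hydroxyphenyl group in place of a 2-hydroxyphenyl group, though at a different position on the shared core, brought a large drop in the number; read in reverse, a 2-hydroxyphenyl group entering would be expected to raise it. The step of a 3.5-fold higher number from compound 1 to compound 3 (0.55 log units; beyond the scatter) shows that a 4-hydroxyphenyl group in place of a 3-hydroxyphenyl group raised the number modestly, so the group that leaves in compound 4 is itself not the most favourable one. Weighing these, a moderate rise beyond the scatter is expected for compound 4, with the step estimated as a 3.4-fold higher number from compound 2 to compound 4 (0.53 log units; beyond the scatter). Compound 4 is therefore estimated at 2500 nM, within a range from 800 nM to 8000 nM.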

Compound 4, half-maximal inhibitory concentration: 130 nM
Compound 4: middle estimate off by 19-fold (1.28 log units), on the high side; measured number outside the range, below it.
By their numbers in this assay, from the lowest: compound 4; then compound 2; then compound 1; then compound 3.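

At the place opposite the ring nitrogen, 2-hydroxyphenyl in place of 4-hydroxyphenyl gave a 5.6-fold lower number from compound 2 to compound 4 (0.75 log units; beyond the scatter) in this assay and put compound 4 lowest of the four numbers. The 2-hydroxyphenyl group therefore has no single direction of effect on the shared core: at a different place, its replacement by 3-hydroxyphenyl gave a 10-fold lower number from compound 1 to compound 2 (1.01 log units; beyond the scatter) as a drop, whereas here its entry brings the number down. Nothing at hand gives a reason for this drop.

From the compounds shown here alone, what a 3-hydroxyphenyl group would give at this same place stays open, and so does whether the hydroxyl itself is needed there, which a methoxy group or an amine on that ring could test. The compounds shown also leave open whether the order of the four numbers would hold in any other cell line.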